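Hydroxamate series: aryl amide swap on compound 1

The source may hold more compounds than are shown below. What is called first, only, known or untested is meant among the compounds shown, and "the series" means these compounds.

Measured so far in an assay on Sf9 cells for inhibition of protein deacetylase HDAC6 (Homo sapiens), read by fluorescence, with stated times of 90 min and 30 min; on this read-out lower numbers stand for stronger inhibition and higher numbers for weaker inhibition:
- compound 1 `Cc1cc(C)cc(C(=O)N(CCC(=O)NCc2ccccc2)Cc2ccc(C(=O)NO)cc2)c1`: 20.5 nM
- compound 2 `CN(C)c1ccc(C(=O)N(CCC(=O)NCc2ccc(Cl)cc2)Cc2ccc(C(=O)NO)cc2)cc1`: 10 nM

Compound 1 holds the higher of the two numbers in this assay; compound 2 gives the lower one, and the gap between the two values is beyond the usual scatter. Going by the values given here, the two compounds differ in two places, so no single step is available between them.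

Compound 3 `CN(C)c1ccc(C(=O)N(CCC(=O)NCc2ccccc2)Cc2ccc(C(=O)NO)cc2)cc1` is the one-place variant of compound 1 with 4-(dimethylamino)phenyl in place of 3,5-dimethylphenyl on a carbonyl carbon. Among the compounds with values here, no measured pair isolates this change; compound 2 carries the same 4-(dimethylamino)phenyl group, together with a chlorine on the benzylamide, and gives 10 nM. On that basis compound 3 is expected to return a lower number than compound 1, a modest step, estimated as a 1.6-fold lower number from compound 1 to compound 3 (0.20 log units; within the scatter). The estimate for compound 3 in this assay is 13 nM, with a likely range from 6 nM to 30 nM.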

Compound 3, half-maximal inhibitory concentration: 14.8 nM
The estimate for compound 3 lay 1.1-fold (0.06 log units) below the measured number; the range from low to high includes it.
By their numbers in this assay, from the lowest: compounds 2, 3 and 1 (each within the scatter of the next, the first and the last beyond it).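

In this assay, 4-(dimethylamino)phenyl in place of 3,5-dimethylphenyl on a carbonyl carbon reads as a 1.4-fold lower number from compound 1 to compound 3 (0.14 log units; within the scatter), so this position accepts either aryl group without a change that can be told from the scatter. Going by these compounds alone, the first single-place reading for the chloro group, hydrogen in place of chloro on an aromatic carbon, is a 1.5-fold higher number from compound 2 to compound 3 (0.17 log units; within the scatter), and it too shows no change that can be told from the scatter. No measurement available here gives a reason for either reading.

Still open, going by these compounds, is whether a phenyl group carrying a carboxylic acid or a morpholine in place of the dimethylamino group would stay within the scatter of compound 3. Also open, on these data alone, is whether the chloro group reads the same alongside 3,5-dimethylphenyl.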